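From Chloro to Methoxy on the Pendant Aryl Ring

The source may report more compounds than this note shows. Statements on the series, on what has been measured and on what is new or still open speak of the compounds shown alone.

The three measured compounds share one core and differ only in the group attached to the sulfur. Compound 1 `CCCCCSc1nc2ccccc2n1CC(=O)O`, which carries a butyl there, gives 1240 nM in an assay on HEK293 cells for displacement of a labelled ligand from prostaglandin D2 receptor 2 (Homo sapiens); a lower number here means a stronger inhibitor, a higher number a weaker inhibitor. Compound 2 `O=C(O)Cn1c(SCc2ccc(Cl)cc2)nc2ccccc21` gives 160 nM in this assay, and compound 3 `O=C(O)Cn1c(SCc2ccccc2Cl)nc2ccccc21` gives 370 nM. Among the three, compound 3 stands second highest: the step of a 3.4-fold lower number from compound 1 to compound 3 (0.53 log units; beyond the scatter) separates it from compound 1, and the step of a 2.3-fold higher number from compound 2 to compound 3 (0.36 log units; beyond the scatter) separates it from compound 2.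

Compound 4 `COc1ccccc1CSc1nc2ccccc2n1CC(=O)O` differs from compound 3 by methoxy in place of chloro on an aromatic carbon. Within the data shown here, none of the measured steps exchanges one substituent for another on that aromatic ring: the steps of a 7.8-fold lower number from compound 1 to compound 2 (0.89 log units; beyond the scatter) and a 3.4-fold lower number from compound 1 to compound 3 (0.53 log units; beyond the scatter) concern a chlorophenyl entering for butyl, and the step of a 2.3-fold higher number from compound 2 to compound 3 (0.36 log units; beyond the scatter) exchanges 4-chlorophenyl for 2-chlorophenyl. Among the measured compounds shown here, they show only that every change at this part of the molecule has so far been modest. For the measured compounds named here, with no direct precedent, the step expected for compound 4 is a 1.1-fold higher number from compound 3 to compound 4 (0.03 log units; within the scatter), with no clear lean in direction and possibly nothing beyond the scatter. Compound 4 is therefore estimated at 400 nM, within a range of 150 nM to 1100 nM.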

Compound 4, half-maximal inhibitory concentration: 1100 nM
Compound 4: the middle estimate sits 2.8-fold (0.44 log units) below what was measured, and the stated range covers the measured number.
By their numbers in this assay, from the lowest: compound 2; then compound 3; then compounds 4 and 1 (each within the scatter of the next).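

Among these compounds, the step of a 3.0-fold higher number from compound 3 to compound 4 (0.47 log units; beyond the scatter) is the first measured change of the substituent itself on this aromatic carbon, with the ring and the place of substitution kept, and in this assay it lies beyond the scatter. Earlier steps changed butyl for a chlorophenyl or 2-chlorophenyl for 4-chlorophenyl, so they could not show that the number also depends on which group stands ortho to the large group: here chloro leaves and methoxy enters, bringing a hydrogen-bond acceptor that chloro lacks, and the step remains modest, like a 2.3-fold higher number from compound 2 to compound 3 (0.36 log units; beyond the scatter). No measurement available here bears on what lies behind this step, so it stays an observed difference without an assigned cause.

As far as these compounds go, whether a methyl, a fluoro or a hydroxyl on the same aromatic carbon would give a number nearer that of compound 3 or that of compound 4 remains open, so one exchange cannot separate the effect of methoxy from that of losing chloro. From the compounds shown here alone, it is also open whether methoxy in place of chloro on the 4-chlorophenyl of compound 2 would give a step of similar size and direction.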